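The source may hold more compounds than are shown below. What is called first, only, known or untested is meant among the compounds shown, and "the series" means these compounds.

Measured compounds and values in an ADME assay on L02 cells (Homo sapiens) for antiproliferative activity, read by CCK-8 assay, with a stated time of 6 days; a lower number here means a stronger inhibitor, a higher number a weaker inhibitor:
- compound 1 `N#Cc1ccc(N2CCc3cc(-c4cnc5ccccc5c4)ccc3C2)cc1C(F)(F)F`: compound 1 gives "not determined" (no result reported)
- compound 2 `N#Cc1ccc(N2CCCc3c(-c4cccnc4)cccc32)cc1C(F)(F)F`: compound 2 gives 10500 nM
- compound 3 `CCN(c1ccc(C#N)c(Cl)c1)c1cc(-c2cccs2)ccc1C`: compound 3 gives "not determined" (no result reported)

Compound 3 therefore stands nowhere on the numbers: it has no value in this assay, and compound 1 is in the same position, with no result either. Among the measured compounds shown here, the only number in the whole set belongs to compound 2, which sits in the weak range of this assay. Nothing can be said about how compound 3 compares with compound 2, since one side of that comparison is missing.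

The step under consideration leads from compound 3 to compound 4 `CCN(c1ccc(C#N)c(Cl)c1)c1cc(-c2cccnc2)ccc1C`, and the structural change is pyridin-3-yl in place of thiophen-2-yl on an aromatic carbon.

For the measured compounds named here, no pair of measured compounds shares this change, so no measured step is available to size it. Given that, and given that the one number in the set, from compound 2, lies in the weak range, the expectation for compound 4 is a value in that same weak region, with no direction assigned beyond the scatter of this assay and a real chance that only a limit is returned.

For compound 4 the estimate in this assay is 12000 nM, with a range from 3000 nM to 45000 nM.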

Compound 4, half-maximal inhibitory concentration: 12700 nM
Compound 4: the middle estimate sits 1.1-fold (0.02 log units) below what was measured; measured number inside the range.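

In this assay, among the compounds shown here, compound 3 gives "not determined" (no result reported) and compound 4 gives 12700 nM so no step from compound 3 to compound 4 can be read. No outside evidence bears on this result. The compounds shown leave open the size and direction of the change from thiophen-2-yl to pyridin-3-yl on this core.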